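Three Imines on a Shared Benzofuranone Core Before a Fourth

The compounds below may be only part of what the source reports. "The series", "measured", "known", "first", "only" and "open" are said of these compounds alone.

Measured so far in a functional assay, with a stated time of 30 min; on this read-out higher numbers stand for weaker inhibition and lower numbers for stronger inhibition:
compound 1 `CCCCc1oc2ccc(/N=C/c3ccccc3)cc2c1C(=O)c1ccc(OC)cc1` gives 34.2 ug/mL
compound 2 `CCCCc1oc2ccc(/N=C/c3ccc([N+](=O)[O-])cc3)cc2c1C(=O)c1ccc(OC)cc1` gives 53.1 ug/mL
compound 3 `CCCCc1oc2ccc(/N=C/c3ccc(Cl)cc3Cl)cc2c1C(=O)c1ccc(OC)cc1` gives 2.44 ug/mL

Compound 3 holds the lowest of the three numbers in this assay. Its nearest neighbour is compound 1, the step being a 14-fold lower number from compound 1 to compound 3 (1.15 log units; beyond the scatter), and the furthest is compound 2, with a 22-fold lower number from compound 2 to compound 3 (1.34 log units; beyond the scatter). Between compound 1 and compound 2 the step is a 1.6-fold higher number from compound 1 to compound 2 (0.19 log units; within the scatter), so these two stand together, and only compound 3 stands apart.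

Compound 4 `CCCCc1oc2ccc(/N=C/c3ccc(OCC)c(OC)c3)cc2c1C(=O)c1ccc(OC)cc1` differs from compound 3 in one place: 4-ethoxy-3-methoxyphenyl in place of 2,4-dichlorophenyl on a carbon with a double bond to nitrogen. For the measured compounds named here, no measured step exchanges one substituted phenyl for another of this kind, so none bears directly on the change. What the measured steps do show is that the aryl group on the carbon with a double bond to nitrogen matters greatly, since the steps from compound 1 and compound 2 to compound 3 are both large. Because the gain seen in a 14-fold lower number from compound 1 to compound 3 (1.15 log units; beyond the scatter) belongs to the 2,4-dichlorophenyl that now leaves, compound 4 is expected to move back toward compound 1 and compound 2, a step of roughly a 10-fold higher number from compound 3 to compound 4 (1.01 log units; beyond the scatter). Compound 4 is therefore estimated at 25 ug/mL, with a range from 6 ug/mL to 80 ug/mL.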

Compound 4, half-maximal inhibitory concentration: 14.8 ug/mL
Compound 4: the middle estimate sits 1.7-fold (0.23 log units) above what was measured; the measured number falls inside the stated range.
By their numbers in this assay, from the lowest: compound 3; then compound 4; then compounds 1 and 2 (each within the scatter of the next).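

For the compounds shown here, the earlier compounds showed only one aryl group on the carbon with a double bond to nitrogen standing apart from the other two, but 4-ethoxy-3-methoxyphenyl now fills part of that gap in this assay and shows that the position gives intermediate read-outs too. With a 2.3-fold lower number from compound 1 to compound 4 (0.36 log units; beyond the scatter) and a 3.6-fold lower number from compound 2 to compound 4 (0.55 log units; beyond the scatter) as its steps from the two weaker imines, a lower number than phenyl no longer depends on chlorine, while 4-nitrophenyl, within the scatter of phenyl, shows that not every substituent gives one. Even so, 2,4-dichlorophenyl keeps a clear lead, as a 6.1-fold higher number from compound 3 to compound 4 (0.78 log units; beyond the scatter) marks the cost of exchanging it for the ethoxy- and methoxy-bearing ring.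

Nothing shown separates the share of the ethoxy group from that of the methoxy group, or of either chlorine, and a phenyl with a single chlorine, a hydroxyl group or a dimethylamino group would test how far these trends hold. No measurement is offered that accounts for the order of these aryl groups.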